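The source may hold more compounds than are shown below. What is called first, only, known or untested is meant among the compounds shown, and "the series" means these compounds.

Compound 1 `COc1cc(-c2nn(-c3cccc(NC(=O)Nc4cc(C(F)(F)F)cc(C(F)(F)F)c4)c3)cc2-c2ccncc2)ccc1Cl` and compound 2 `O=C(Nc1cccc(-n2cc(-c3ccncc3)c(-c3ccc(Cl)c(O)c3)n2)c1)Nc1cc(C(F)(F)F)cc(C(F)(F)F)c1` form the first matched pair. In a functional assay on SNB-75 cells (Homo sapiens) for inhibition, read by sulforhodamine B assay, with a stated time of 48 h (a higher number here means a weaker inhibitor of growth, a lower number a stronger inhibitor of growth), compound 1 gives 2070 nM, and in this assay compound 2 gives 2180 nM. The change between them is hydrogen in place of methyl on an oxygen on an aromatic ring, and the step it made was a 1.1-fold higher number from compound 1 to compound 2 (0.02 log units; within the scatter), so the two values do not separate from one another.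

Compound 3 `COc1cc(-c2nn(-c3cccc(NC(=O)Nc4ccc(Cl)c(C(F)(F)F)c4)c3)cc2-c2ccncc2)ccc1Cl` carries a different core; the difference between the core of compound 3 and the core of compound 1 is not broken down here. In this assay, among the measured compounds shown here, compound 3 gives 10300 nM, the highest of the three numbers so far, lying beyond the scatter from both compound 1 and compound 2.

Compound 4 `O=C(Nc1cccc(-n2cc(-c3ccncc3)c(-c3ccc(Cl)c(O)c3)n2)c1)Nc1ccc(Cl)c(C(F)(F)F)c1` has not yet been measured. It differs from compound 3 by hydrogen in place of methyl on an oxygen on an aromatic ring, and this is the same change that was made from compound 1 to compound 2, at the same place. For the measured compounds named here, since that earlier step was within the scatter, the expectation is that the step from compound 3 to compound 4 in this assay will also be small, estimated at a 1.1-fold higher number from compound 3 to compound 4 (0.03 log units; within the scatter), resting on the single earlier instance a 1.1-fold higher number from compound 1 to compound 2 (0.02 log units; within the scatter). Compound 4 is therefore expected to stay close to compound 3, and its estimated value in this assay is 11000 nM, with a likely range from 5000 nM to 25000 nM.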

Compound 4, concentration for total growth inhibition: 3200 nM
The estimate for compound 4 lay 3.4-fold (0.54 log units) above the measured number, outside the stated range (below it).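

On the core of compound 3, exchanging methoxy for hydroxy gave a clear gain in this assay, with a 3.2-fold lower number from compound 3 to compound 4 (0.51 log units; beyond the scatter), so the change that had made no separable difference on the core of compound 1 did make one here. Set side by side, the two steps show that the effect of this change does not carry over unaltered from one core to the other in this series, and that a step measured on one core is a poor guide to the step on the other: the same change on two cores in this assay, a 1.1-fold higher number (0.02 log units; within the scatter) from compound 1 to compound 2 and a 3.2-fold lower number (0.51 log units; beyond the scatter) from compound 3 to compound 4, 3.4-fold (0.53 log units) apart, beyond the scatter of two such steps. This rests on one pair per core, however, so it shows that the outcome depends on the core, but it does not show which feature of the cores is responsible, nor does it establish a general rule that hydroxy is favoured or neutral.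

Left open is whether an ethoxy group or an amine at the same place on the 4-chloro-3-methoxyphenyl ring would follow the methoxy or the hydroxy result on either core. Also open, as far as these compounds go, is whether a third core would repeat the flat step of the core of compound 1, the larger step of the core of compound 3, or neither.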